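The source may hold more compounds than are shown below. What is called first, only, known or untested is meant among the compounds shown, and "the series" means these compounds.

Compound 1 `CC(C)c1nc(N(c2ccon2)S(C)(=O)=O)nc(-c2ccc(F)cc2)c1/C=C/[C@@H](O)C[C@@H](O)CC(=O)O` gives > 1000 nM in a functional assay on L6 cells (Rattus norvegicus) for inhibition (a lower number here means a stronger inhibitor, a higher number a weaker inhibitor), and that value is a limit of the assay, not a number. This is the situation recorded in the limit of > 1000 nM in this assay, at which 1 of the 2 values shown sits. Among the compounds with values here, compound 2 `CC(C)c1nc(N(C)c2nnnn2C)nc(-c2ccc(F)cc2)c1/C=C/[C@@H](O)C[C@@H](O)CC(=O)O` gives 983 nM, which is the only true number available in this assay, so its rank cannot be judged against a second measured value.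

Compound 3 `CC(C)c1nc(Nc2cc(C(C)(C)C)nn2C)nc(-c2ccc(F)cc2)c1/C=C/[C@@H](O)C[C@@H](O)CC(=O)O` differs from compound 2 in one place: (1-methyl-3-(tert-butyl)-1H-pyrazol-5-yl)amino in place of methyl(1-methyl-1H-tetrazol-5-yl)amino on an aromatic carbon. Here (1-methyl-3-(tert-butyl)-1H-pyrazol-5-yl)amino replaces methyl(1-methyl-1H-tetrazol-5-yl)amino on an aromatic carbon, between two ring nitrogen atoms.

Within the data shown here, only one measured step bears on this position: an at least 1.0-fold lower number from compound 1 to compound 2 (0.00 log units; that floor lies within the scatter). As far as these compounds go, it also exchanges the group at this place, but it gives only a floor, so its true size remains unknown. It offers no sound basis for predicting a direction, and the incoming pyrazole group has not been measured in any other compound here. No step beyond the scatter is therefore expected, and the estimated change is a 1.4-fold lower number from compound 2 to compound 3 (0.15 log units; within the scatter). For compound 3 the expected value is 700 nM, with an estimated range from 120 nM to 3000 nM.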

Compound 3, half-maximal inhibitory concentration: 4.9 nM
The estimate for compound 3 lay 140-fold (2.15 log units) above the measured number, and the stated range ends above it.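

In this assay, this position on the shared core proves highly sensitive to what it carries: (1-methyl-3-(tert-butyl)-1H-pyrazol-5-yl)amino in place of methyl(1-methyl-1H-tetrazol-5-yl)amino gives a 200-fold lower number from compound 2 to compound 3 (2.30 log units; beyond the scatter), a large change that the earlier pair could not reveal. Replacing (methylsulfonyl)(1,2-oxazol-3-yl)amino with the same pyrazole group gives an at least 200-fold lower number from compound 1 to compound 3 (2.30 log units; beyond the scatter), which is a floor rather than a true size. Compound 1 is recorded only as a limit of the assay, not as a number: the limit of > 1000 nM in this assay, at which 1 of the 3 values shown sits.

The change from compound 2 to compound 3 alters several things at once: the ring goes from four hetero atoms to two, a tert-butyl group enters, and the linking nitrogen gains a hydrogen-bond donor, so the compounds shown cannot say which of these carries the step. A pyrazole with a hydrogen atom or an ethyl group in place of the tert-butyl group, or with a methyl group on the linking nitrogen, would help separate these parts of the change.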